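The source may report more compounds than this note shows. Statements on the series, on what has been measured and on what is new or still open speak of the compounds shown alone.

Measured so far in an assay on CHO cells for displacement of a labelled ligand from adenosine receptor A3 (Homo sapiens), read by scintillation counting, with a stated time of 3 h; a higher number here means a weaker inhibitor, a lower number a stronger inhibitor:
compound 1 `CCn1c(-c2ccccc2)nc2c(NC3CCC3)ncnc21` gives 84 nM
compound 2 `CCCn1c(-c2ccccc2)nc2c(NC3CCC3)ncnc21` gives 264 nM
compound 3 `Cn1c(-c2ccccc2)nc2c(NC3CCC3)ncnc21` gives 280 nM

Compound 2 stands second highest of these three numbers in this assay. Its nearest neighbour is compound 3, the step of a 1.1-fold higher number from compound 2 to compound 3 (0.03 log units; within the scatter) lying within the scatter, so the two cannot be ordered. Its furthest neighbour is compound 1, the step of a 3.1-fold higher number from compound 1 to compound 2 (0.50 log units; beyond the scatter) lying beyond the scatter and counting as modest.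

Compound 4 `CCCn1c(-c2ccccc2)nc2c(N)ncnc21` differs from compound 2 in one place: hydrogen in place of cyclobutyl on a nitrogen on an aromatic ring. For the measured compounds named here, no measured step touches that nitrogen. The two steps that lie beyond the scatter, a 3.1-fold higher number from compound 1 to compound 2 (0.50 log units; beyond the scatter) and a 3.3-fold higher number from compound 1 to compound 3 (0.52 log units; beyond the scatter), both concern the saturated chain on the aromatic nitrogen of the shared core, and each was modest. The step to compound 4 removes a whole ring of four carbons rather than shifting a single methyl, so it is a larger change than any step measured here, and its direction is not shown by the data.

Given that, a step larger than the modest ones, toward a higher number, is expected, a 19-fold higher number from compound 2 to compound 4 (1.28 log units; beyond the scatter). For compound 4 the estimate in this assay is 5000 nM, within a range from 800 nM to 30000 nM.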

Compound 4, inhibition constant: 9280 nM
Compound 4: the middle estimate sits 1.9-fold (0.27 log units) below what was measured; measured number inside the range.
By their numbers in this assay, from the lowest: compound 1; then compounds 2 and 3 (each within the scatter of the next); then compound 4.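

On the nitrogen on an aromatic ring, the change from cyclobutylamino to amino gives a 35-fold higher number from compound 2 to compound 4 (1.55 log units; beyond the scatter) in this assay, a large step, while the steps among compounds 1, 2 and 3, all on the saturated chain on the aromatic nitrogen of the shared core, were modest or lay within the scatter. The earlier compounds shown here all carried the cyclobutyl group and so said nothing about this position; this pair shows that its removal goes toward a weaker inhibitor and outweighs any change of chain seen so far. Nothing at hand explains why the loss of this four-membered ring has so large an effect on the number.

The compounds shown leave open whether the ring itself matters or whether any group on that nitrogen would serve, as a methyl, an open butyl chain or a cyclopentyl ring might tell. They also leave open whether the same change would be as large on the ethyl-bearing core of compound 1 or the methyl-bearing core of compound 3, since it is seen here only with the propyl chain of compound 2.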